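This account rests on a few compounds, and the source may have more. Where it says the series, first, only, none or still open, it means among the compounds named here.

Measured in a functional assay on KYSE-450 cells (Homo sapiens) for inhibition, read by CCK-8 assay, with a stated time of 48 h; on this read-out lower numbers stand for stronger inhibition and higher numbers for weaker inhibition:
compound 1 `COc1ccc(CN(C(=O)CSC(=S)N2CCN(C(=O)OC(C)(C)C)CC2)c2cc(OC)c(OC)c(OC)c2)cc1`: 250 nM
compound 2 `COc1ccc(CN(C(=O)CSC(=S)N2CCN(C(=O)OC(C)(C)C)CC2)c2cc(OC)c(OC)c(OC)c2)cc1OC`: > 20000 nM

For compound 2 the reading is only a limit, > 20000 nM, and not a number. Compound 3 `COc1ccc(CN(C(=O)CSC(=S)N2CCN(C(=O)OC(C)(C)C)CC2)c2cc(OC)c(OC)c(OC)c2)cc1C` carries methyl in place of methoxy on an aromatic carbon, ortho to a methoxy group (methyl in place of methoxy on an aromatic carbon). Going by the values given here, the one measured step at this carbon, an at least 80-fold higher number from compound 1 to compound 2 (1.90 log units; beyond the scatter), was large and came with methoxy in place of hydrogen. Losing that methoxy is therefore expected to bring a clear move to lower numbers in this assay, though probably not all the way back, since a group remains there. The expected step is an at least 8.0-fold lower number from compound 2 to compound 3 (0.90 log units; beyond the scatter). Compound 3 is estimated at 2500 nM, with an expected range of 300 nM to 20000 nM.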

Compound 3, half-maximal inhibitory concentration: > 20000 nM
Compound 3: only a limit was reported; the forecaster's own chance of this, stated with the estimate: 30%; at least 8.0-fold (0.90 log units) between middle value and limit.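

In this assay, a group without oxygen at this aromatic carbon also costs activity: methyl in place of hydrogen gives an at least 80-fold higher number from compound 1 to compound 3 (1.90 log units; beyond the scatter). The loss at this carbon is therefore not tied to methoxy alone, and among the compounds shown only hydrogen there gives a measurable value. The step between compound 2 and compound 3 cannot be read, because both readings are limits and not numbers: the limit of > 20000 nM in this assay, at which 2 of the 3 values shown sit.

As far as these compounds go, it remains open whether fluorine or hydroxyl at this carbon would keep a measurable value. From the compounds shown here alone, how far compound 2 and compound 3 lie beyond their shared limit also remains open.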